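Isopropyl for propyl on the ring nitrogen

A few compounds are considered here, and "the series" means these few. Any claim that something is new, unique, unknown or untested is made for them only; others in the source may bear on it.

In a functional assay on cells (Platelet, Homo sapiens) for inhibition (on this read-out lower numbers stand for stronger inhibition and higher numbers for weaker inhibition), compound 1 (`CCOC(=O)c1ccc(-c2nn(Cc3ccc(OC)cc3)c3ccccc23)cc1`) gives 620 nM and compound 2 (`CCOC(=O)c1ccc(-c2nn(CC)c3ccccc23)cc1`) gives 360 nM while compound 3 (`CCCn1nc(-c2ccc(C(=O)OCC)cc2)c2ccccc21`) gives 490 nM on the same read-out. The three values lie within the scatter of one another, and compound 3 stands closest to compound 1 without being separable from either neighbour.

Compound 4 (`CCOC(=O)c1ccc(-c2nn(C(C)C)c3ccccc23)cc1`) has isopropyl in place of propyl on an aromatic nitrogen and keeps the rest of the core of compound 3 unchanged.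

Going by the values given here, three measured steps concern the same nitrogen substituent. The two replacements of 4-methoxyphenyl (a 1.7-fold lower number from compound 1 to compound 2 (0.24 log units; within the scatter)) and (a 1.3-fold lower number from compound 1 to compound 3 (0.10 log units; within the scatter)) stay within the scatter. Among the compounds with values here, the lengthening of the chain by methyl in place of hydrogen (a 1.4-fold higher number from compound 2 to compound 3 (0.13 log units; within the scatter)) is the closest precedent and also stays within the scatter. Within the data shown here, no compound measured so far has a branched chain on that nitrogen, so the effect of branching itself remains untested.

With every measured change at this nitrogen this small, the step (a 1.1-fold lower number from compound 3 to compound 4 (0.06 log units; within the scatter)) is expected to stay within the scatter, with no direction favoured. The estimated value for compound 4 is 430 nM with an expected range from 210 nM to 880 nM in this assay overall.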

Compound 4, half-maximal inhibitory concentration: 650 nM
For compound 4 the middle estimate is 1.5-fold (0.18 log units) below the measured one; the range from low to high includes it.
By their numbers in this assay, from the lowest: compounds 2, 3, 1 and 4 (each within the scatter of the next).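

Working notes on the ring nitrogen: in this assay, the first branched chain at this position gives no separable shift from its straight isomer with the same atoms joined differently (a 1.3-fold higher number from compound 3 to compound 4 (0.12 log units; within the scatter)), so moving from propyl to isopropyl shows no measurable effect of branching here. The comparison with the shorter ethyl chain (a 1.8-fold higher number from compound 2 to compound 4 (0.26 log units; within the scatter)) is the widest gap among the steps at this nitrogen and is still within the scatter, while the one with the much larger 4-methoxybenzyl group (a 1.0-fold higher number from compound 1 to compound 4 (0.02 log units; within the scatter)) is the narrowest. Ethyl, propyl, isopropyl and 4-methoxybenzyl therefore all lie within the scatter of one another, and this assay does not rank these four substituents.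

As far as these compounds go, whether an amine on the chain, a longer chain or a carboxylic acid in place of the ethyl ester would give a step beyond the scatter remains open. No accompanying measurement offers an explanation for the similar readings of these four compounds.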